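The compounds below may be only part of what the source reports. "The series", "measured", "known", "first", "only" and "open" are said of these compounds alone.

Compound 1 `CCC1(Cc2ccccc2)OS(=O)(=O)C=C1OCC(=O)OC` stands in an ADME assay on HEL cells (Homo sapiens) for cytotoxicity, with a stated time of 3 days (on this read-out lower numbers stand for higher toxicity in this test and higher numbers for lower toxicity in this test), at > 200000 nM, which is a limit of the assay rather than a number. Compound 2 `CCC1(Cc2ccccc2)OS(=O)(=O)C=C1OCC#N` likewise reaches only a limit in this assay, > 200000 nM. Compound 3 `CC1(C(c2ccccc2)c2ccccc2)OS(=O)(=O)C=C1OCc1ccccc1` gives 200000 nM in this assay. The step that the two limits leave unreadable from compound 1 to compound 2 is therefore unreadable, both of its end points sitting at the limit of > 200000 nM in this assay, at which 2 of the 3 values shown sit. Compound 4 `CCC1(Cc2ccccc2)OS(=O)(=O)C=C1OCc1ccc(OC)cc1` differs from compound 1 by 4-methoxyphenyl in place of methoxycarbonyl on a saturated chain carbon bound to an oxygen on an unsaturated carbon. Within the data shown here, no measured step covers this exchange, the only comparison available is unreadable, and compound 1 itself is known only as a limit, so no direction can be read for it. Compound 4 is therefore expected to show no step beyond the scatter, a number no higher from compound 1 to compound 4 (the limit leaves the size open), and its estimated value in this assay is 200000 nM, between 100000 nM and 400000 nM.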

Compound 4, half-maximal cytotoxic concentration: > 200000 nM
Compound 4: a limit, no number (the forecaster's own chance of this, stated with the estimate: 70%); the middle value sits exactly at the limit.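

Compound 4 gives > 200000 nM in this assay, which is a limit and not a number. The steps to it from compound 1 and from compound 2 cannot be read. The compounds shown leave open whether exchanging these groups changes the read-out at all.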